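Cyanomethyl in place of allyl on a sulfanyl chain

A few compounds are considered here, and "the series" means these few. Any claim that something is new, unique, unknown or untested is made for them only; others in the source may bear on it.

Compound 1 `C#CCSc1nc2cc(Cl)c(Cl)cc2n1C1O[C@H](CO)[C@@H](O)[C@H]1O`: 60000 nM
Compound 2 `C=CCSc1nc2cc(Cl)c(Cl)cc2n1C1O[C@H](CO)[C@@H](O)[C@H]1O`: 68000 nM

Two compounds share the same core and differ only in the chain bound to the sulfur. In a functional assay on KB cells (Homo sapiens) for inhibition (a higher number here means a weaker inhibitor, a lower number a stronger inhibitor), compound 1 gives 60000 nM, and compound 2 gives 68000 nM. Within the data shown here, the only measured step, a 1.1-fold higher number from compound 1 to compound 2 (0.05 log units; within the scatter), changes nothing beyond the scatter. Compound 2 thus stands at the higher of the two numbers, but it is not separated from compound 1 in this assay.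

Compound 3 `N#CCSc1nc2cc(Cl)c(Cl)cc2n1C1O[C@H](CO)[C@@H](O)[C@H]1O` continues from compound 2 with the change (cyano in place of vinyl on a saturated chain carbon bound to a sulfur). Among the measured compounds shown here, no measured step exchanges a vinyl for a cyano group, so the only guidance is indirect: the step from an ethynyl to a vinyl group on this chain carbon left the number essentially where it was. Since one small two-atom group on this chain has so far been interchangeable with another, compound 3 is expected to land close to compound 2, with the step of a 1.0-fold higher number from compound 2 to compound 3 (0.01 log units; within the scatter) estimated as a change within the scatter. For compound 3 the expected value in this assay is 70000 nM, with a range from 25000 nM to 200000 nM.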

Compound 3, half-maximal inhibitory concentration: > 100000 nM
Compound 3 was reported as a limit (the forecaster's own chance of this, stated with the estimate: 20%); middle value at least 1.4-fold (0.15 log units) from the limit.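

In this assay, among these compounds, compound 3 is the only one of the three compounds that gives a limit of the assay and not a number: the limit of > 100000 nM in this assay, at which 1 of the 3 values shown sits.

Among the compounds shown here, the cyano group, which enters with one hydrogen-bond acceptor where the vinyl group has none, thus gives the first reading on this saturated chain carbon bound to a sulfur that has no upper end, whereas the ethynyl and vinyl groups gave values within the scatter of each other. Even so, the result reads only as an at least 1.4-fold higher number from compound 2 to compound 3 (0.16 log units; that floor lies within the scatter) and as an at least 1.6-fold higher number from compound 1 to compound 3 (0.22 log units; that floor lies within the scatter), and both floors lie within the scatter, so the data do not separate compound 3 from compound 2 or compound 1.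

As far as these compounds go, how far the true value of compound 3 lies from those of the other two compounds stays open, and the limit cannot settle whether the cyano group changes the read-out at all. Also open, from the compounds shown here alone, is how an amine or a carboxylic acid on this chain carbon, or a longer chain bound to the sulfur, would read in this assay.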